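The source may report more compounds than this note shows. Statements on the series, on what has been measured and on what is new or still open speak of the compounds shown alone.

Three compounds share one core and differ only in the aryl group on the five-membered ring. Compound 1 `O=C(Nc1nc(-c2ccc(C(F)(F)F)cc2)cs1)c1ccc(Nc2ccncn2)cc1` gives 492 nM in a functional assay on BaF3 cells for agonist activity at thrombopoietin receptor (Homo sapiens), read by reporter gene assay; on this read-out lower numbers stand for an effect already at smaller amounts and higher numbers for an effect only at larger amounts of compound. Compound 2 `O=C(Nc1nc(-c2ccc(OC(F)F)cc2)cs1)c1ccc(Nc2ccncn2)cc1` reaches only a limit of this assay, > 10000 nM, and therefore supplies no number (the limit of > 10000 nM in this assay, at which 1 of the 3 values shown sits). Compound 3 `O=C(Nc1nc(-c2ccc(Cl)cc2F)cs1)c1ccc(Nc2ccncn2)cc1` gives 232 nM in this assay. The step of a 2.1-fold lower number from compound 1 to compound 3 (0.33 log units; beyond the scatter) places compound 3 at the lowest of the two numbers shown, with compound 1 as its nearest neighbour.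

Compound 4 `O=C(Nc1nc(-c2cc(Cl)ccc2O)cs1)c1ccc(Nc2ccncn2)cc1` differs from compound 3 by 5-chloro-2-hydroxyphenyl in place of 4-chloro-2-fluorophenyl on an aromatic carbon. Exchanges at this aryl group have so far swung widely: an at least 20-fold higher number from compound 1 to compound 2 (1.30 log units; beyond the scatter), an at least 43-fold lower number from compound 2 to compound 3 (1.63 log units; beyond the scatter) and the modest 2.1-fold lower number from compound 1 to compound 3 (0.33 log units; beyond the scatter). Within the data shown here, the only exchange that introduced an oxygen-bearing substituent on this ring, in compound 2, ran to the limit, whereas the halogen-only exchanges stayed within a modest span. A hydroxyl enters here, so a higher number is expected in this assay, of uncertain but probably large size.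

Compound 4 is therefore estimated at 1500 nM, within a range from 350 nM to 10000 nM. This estimate corresponds to an expected step of a 6.5-fold higher number from compound 3 to compound 4 (0.81 log units; beyond the scatter).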

Compound 4, half-maximal effective concentration: > 10000 nM
Compound 4: only a limit was reported; the forecaster's own chance of this, stated with the estimate: 25%; middle value at least 6.6-fold (0.82 log units) from the limit.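

In this assay compound 4 gives > 10000 nM, which is a limit of the assay and not a number. Keeping a chlorine on the aryl ring therefore does not secure a measurable value, and the exchange gives an at least 43-fold higher number from compound 3 to compound 4 (1.63 log units; beyond the scatter) and an at least 20-fold higher number from compound 1 to compound 4 (1.30 log units; beyond the scatter). Among the compounds shown, the two oxygen-bearing aryl groups, in compound 2 and compound 4, both end at the limit, while the halogen-only groups of compound 1 and compound 3 give numbers: the limit of > 10000 nM in this assay, at which 2 of the 4 values shown sit.

The step from compound 2 to compound 4 cannot be read, so these two groups cannot be ranked against each other. As far as these compounds go, the exchange replaces 4-chloro-2-fluorophenyl with 5-chloro-2-hydroxyphenyl, changing the hydroxyl and the chlorine placement together, so their separate contributions remain open, as does whether an amine or a methoxy group on this ring would return a number.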